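The source may hold more compounds than are shown below. What is called first, only, known or untested is meant among the compounds shown, and "the series" means these compounds.

Measured so far in a functional assay on cells for inhibition of Polyunsaturated fatty acid 5-lipoxygenase (Homo sapiens); on this read-out higher numbers stand for weaker inhibition and lower numbers for stronger inhibition:
compound 1 `O=C1NCCN(c2cccc(Cl)c2)N1`: 2100 nM
compound 2 `Cc1cccc(N2CC(C)NC(=O)N2)n1`: 1700 nM

Of the two numbers, compound 2 has the smaller one in this assay, its nearest being compound 1; the gap between them is within the scatter, so the two are taken as equivalent. Compound 3 `CC1CN(c2cccc(Cl)n2)NC(=O)N1` follows from compound 2 by chloro in place of methyl on an aromatic carbon. Going by the values given here, no measured pair differs at this place alone, so the size of this step in this assay is not known; no step beyond the scatter is expected in either direction. The expected value of compound 3 in this assay is 1500 nM, with a range of 500 nM to 4500 nM. This estimate means a step of a 1.1-fold lower number from compound 2 to compound 3 (0.05 log units; within the scatter).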

Compound 3, half-maximal inhibitory concentration: 1600 nM
Compound 3: the middle estimate sits 1.1-fold (0.03 log units) below what was measured, and the stated range covers the measured number.
By their numbers in this assay, from the lowest: compounds 3, 2 and 1 (each within the scatter of the next).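

In this assay, chloro in place of methyl on the aromatic carbon next to the ring nitrogen gives a 1.1-fold lower number from compound 2 to compound 3 (0.03 log units; within the scatter) and so shows that this position accepts either group with no step beyond the scatter. Compound 1 and compound 2 differ in more than one place, so they gave no reading of this position alone. Nothing measured here bears on why the two groups read alike. Open, going by these compounds, is whether a larger or different group at this position, such as methoxy, an amine or a carboxylic acid, would move the number beyond the scatter.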